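The source may hold more compounds than are shown below. What is called first, only, known or untested is meant among the compounds shown, and "the series" means these compounds.

In a physicochemical assay for lipophilicity, at pH 7.4 (a lower number here means a more polar compound, a higher number a more lipophilic compound), compound 1 `CC(C)(C(=O)O)c1nn(Cc2cn3cc(OCC4CC4)c(Cl)cc3n2)c2ccccc2c1=O` gives 2.95 and compound 2 `CCC(C(=O)O)c1nn(Cc2cn3cc(OCC4CC4)c(Cl)cc3n2)c2ccccc2c1=O` gives 2.71. Among the measured compounds shown here, these two numbers lie within the scatter of each other, so compound 2 stands level with the only other measured compound. Compound 3 `C[C@H](C(=O)O)c1nn(Cc2cn3cc(OCC4CC4)c(Cl)cc3n2)c2ccccc2c1=O` changes one group of compound 2: 1-carboxyethyl in place of 1-carboxypropyl on an aromatic carbon. In words, 1-carboxyethyl takes the place of 1-carboxypropyl on an aromatic carbon, and the rest of the molecule stays the same. For the measured compounds named here, only one measured step bears on this change, and only loosely: a number 0.24 log units lower from compound 1 to compound 2 (within the scatter). Going by the values given here, that step rearranged the carbons of this side chain without removing any, and no measured step removes a carbon from it. A small downward move, no larger than the scatter, is therefore expected, and the expected step is a number 0.26 log units lower from compound 2 to compound 3 (within the scatter). For compound 3 the estimated value is 2.45, with an expected range from 2.15 to 2.75.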

Compound 3, distribution coefficient: 2.39
Estimate against measurement, compound 3: 0.06 log units above; low and high end bracket the measured number.
By their numbers in this assay, from the lowest: compound 3; then compounds 2 and 1 (each within the scatter of the next).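

In this assay, among the compounds shown here, replacing 1-carboxypropyl (6 heavy atoms) with 1-carboxyethyl (5 heavy atoms) on this aromatic carbon gives a number 0.32 log units lower from compound 2 to compound 3 (beyond the scatter), the first change at this position to move the number past the scatter. Replacing 1-carboxy-1-methylethyl with the same group gives a number 0.56 log units lower from compound 1 to compound 3 (beyond the scatter), so compound 3 stands apart from both earlier compounds, which remain within the scatter of each other. Nothing measured here accounts for this drop.

The compounds shown leave open whether carboxymethyl, a still shorter side chain, would continue the downward move, or whether an amine in place of the carboxylic acid would shift the number at all. They also leave open whether the defined stereocentre of compound 3 contributes to its step, as its mirror-image form does not appear among them.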